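Four related compounds in a cell cytotoxicity assay

The compounds below may be only part of what the source reports. "The series", "measured", "known", "first", "only" and "open" are said of these compounds alone.

Compound 1 `O=C(/C=C/c1ccc(OCCCCCO[N+](=O)[O-])c(O)c1)OCCCCCO[N+](=O)[O-]` was tested in a functional assay on HOP-62 cells (Homo sapiens) for cytotoxicity, read by resazurin assay, with a stated time of 72 h; on this read-out higher numbers stand for weaker inhibition and lower numbers for stronger inhibition. In this assay compound 1 gives only a limit, > 50000 nM. Compound 3 `COc1cc(/C=C/C(=O)OCCCCCO[N+](=O)[O-])ccc1OCCCCCO[N+](=O)[O-]` differs from compound 1 by methyl in place of hydrogen on an oxygen on an aromatic ring. In this assay compound 3 also gives only a limit, > 50000 nM. Because both values are limits, the step that the two limits leave unreadable from compound 1 to compound 3 cannot be read. Compound 2 `O=C(/C=C/c1ccc(OCCCCO[N+](=O)[O-])c(O)c1)OCCCCO[N+](=O)[O-]` has a different core; the difference between the cores of compound 1 and compound 2 is not broken down here. In this assay compound 2 gives only a limit as well, > 50000 nM. All three measured values thus sit at the same point, (the limit of > 50000 nM in this assay, at which 3 of the 3 values shown sit).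

Compound 4 `COc1cc(/C=C/C(=O)OCCCCO[N+](=O)[O-])ccc1OCCCCO[N+](=O)[O-]` has not yet been measured. Going by the values given here, it differs from compound 2 by methyl in place of hydrogen on an oxygen on an aromatic ring, which is the same change as the one from compound 1 to compound 3, made at the same kind of place on the aromatic ring. Among the compounds with values here, the expected step that the limit leaves unreadable from compound 2 to compound 4 rests on the observation that the only comparable pair, compound 1 and compound 3, shows no readable movement and that every measured value sits at the limit of > 50000 nM in this assay, at which 3 of the 3 values shown sit. Compound 4 is therefore expected to give 60000 nM in this assay, most likely again as a limit rather than a number, with a plausible range from 30000 nM to 200000 nM.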

Compound 4, half-maximal inhibitory concentration: > 50000 nM
Compound 4: only a limit was reported; the forecaster's own chance of this, stated with the estimate: 85%; the middle value lies beyond the limit too.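

In this assay compound 4 gives only a limit, > 50000 nM. Compound 2 also gives only a limit, so no step can be read from compound 2 to compound 4, and the compounds share a single reading: the limit of > 50000 nM in this assay, at which 4 of the 4 values shown sit. The compounds shown leave open whether the change from hydroxy to methoxy has any effect on the result in this assay, and what real potency, if any, lies beyond that limit.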